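Acetyl in place of hydrogen on compound 2

A few compounds are considered here, and "the series" means these few. Any claim that something is new, unique, unknown or untested is made for them only; others in the source may bear on it.

Measured in a physicochemical assay for solubility, at pH 7.4; on this read-out higher numbers stand for higher solubility and lower numbers for lower solubility:
Compound 1 `CC(=O)OCCCc1ccc(S(N)(=O)=O)cc1`: 1600 ug/mL
Compound 2 `NS(=O)(=O)c1ccc(CCCCCO)cc1`: 2600 ug/mL

Within the data shown here, on these numbers, compound 2 stands within the scatter of compound 1, the only other compound measured in this assay. Compound 3 `CC(=O)OCCCCCc1ccc(S(N)(=O)=O)cc1` has not yet been measured. It differs from compound 2 by acetyl in place of hydrogen on an oxygen on a saturated carbon, which can also be read as hydroxy to acetoxy.

Among the measured compounds shown here, only one measured step bears on this change: a 1.6-fold higher number from compound 1 to compound 2 (0.21 log units; within the scatter). That step put 2-hydroxyethyl in place of acetoxy, so it runs broadly the opposite way, though it lies within the scatter. For the measured compounds named here, it also differs in the chain, and no measured step shows the acetyl change alone. A modest move toward a lower number is therefore expected, and it may not clear the scatter. The expected step is a 2.2-fold lower number from compound 2 to compound 3 (0.34 log units; beyond the scatter). For compound 3 the estimated value is 1200 ug/mL, with an expected range from 400 ug/mL to 2600 ug/mL.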

Compound 3, solubility: 1200 ug/mL
Estimate against measurement, compound 3: no gap at the digits printed, and the stated range covers the measured number.
By their numbers in this assay, from the lowest: compounds 3, 1 and 2 (each within the scatter of the next, the first and the last beyond it).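

In this assay, the change from hydroxy to acetoxy can now be read on its own, with the chain held constant, and it gives a 2.2-fold lower number from compound 2 to compound 3 (0.34 log units; beyond the scatter). This is a modest step, but it clears the scatter, whereas the earlier step between compound 1 and compound 2 changed the chain as well and stayed within the scatter. With acetoxy kept in place, the difference in chain gives a 1.3-fold lower number from compound 1 to compound 3 (0.12 log units; within the scatter), so compound 1 and compound 3 stand within the scatter of each other, and there is no independent evidence here to account for either step.

The compounds shown leave open whether the same step would appear with a hydroxy group on the chain of compound 1, since only one chain length provides a direct comparison of hydroxy and acetoxy. They also leave open how a propionyl or benzoyl ester, a methyl ether, an amine or a carboxylic acid would read at this position, and whether a longer chain would keep compound 3 within the scatter of compound 1.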